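Swapping a Cyano Group for an Amino Group

This account rests on a few compounds, and the source may have more. Where it says the series, first, only, none or still open, it means among the compounds named here.

Among the measured compounds shown here, compound 2 `N#Cc1cncc(OC[C@@H]2CCN2)c1` gives 0.025 nM in an assay on brain for binding affinity to Neuronal acetylcholine receptor; alpha4/beta2 (Rattus norvegicus), read by radioligand binding (a higher number here means a weaker inhibitor, a lower number a stronger inhibitor), the lowest of the two numbers measured so far. Compound 1 `Clc1cncc(OC[C@@H]2CCN2)c1` gives 0.042 nM in this assay, and the step of a 1.7-fold lower number from compound 1 to compound 2 (0.23 log units; within the scatter) stayed within the scatter. Compound 3 `Nc1cncc(OC[C@@H]2CCN2)c1` has not been measured yet; it differs from compound 2 by amino in place of cyano on an aromatic carbon. For the measured compounds named here, only one measured step touches this position, and it involved a different pair of groups, so it gives little direct guidance. A modest rise in the number is expected, a 12-fold higher number from compound 2 to compound 3 (1.08 log units; beyond the scatter). Compound 3 is estimated at 0.3 nM, within a range from 0.05 nM to 2 nM.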

Compound 3, inhibition constant: 0.082 nM
For compound 3 the middle estimate is 3.7-fold (0.56 log units) above the measured one; the measured number falls inside the stated range.
By their numbers in this assay, from the lowest: compounds 2, 1 and 3 (each within the scatter of the next, the first and the last beyond it).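

In this assay, among the compounds shown here, amino in place of cyano gives a 3.3-fold higher number from compound 2 to compound 3 (0.52 log units; beyond the scatter) and is the first step at this position to pass the scatter, so the group placed here can shift the number, if only modestly. Amino in place of chloro gives a 2.0-fold higher number from compound 1 to compound 3 (0.29 log units; within the scatter) and leaves compound 1 and compound 3 indistinguishable in this assay. Nothing available explains why cyano and amino differ here.

Still open, on these data alone, is how a methyl group, a carboxylic acid or a longer chain would fare at this position. Also open, as far as these compounds go, is whether the step from cyano to amino would be similar on a different core.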